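Removing a Methyl Group: From Compound 3 to Compound 4

The source may hold more compounds than are shown below. What is called first, only, known or untested is meant among the compounds shown, and "the series" means these compounds.

Measured so far in an assay on HEK293 cells for inhibition of acid ceramidase (Homo sapiens), read by fluorescence, with stated times of 30 min and 1 h; on this read-out higher numbers stand for weaker inhibition and lower numbers for stronger inhibition:
compound 1 `COc1nc2ccccc2n1C(=O)NCCCCc1ccccc1` gives 13.9 nM;
compound 2 `Cc1ccccc1CNC(=O)n1cnc2ccccc21` gives 55.9 nM;
compound 3 `Cc1ccccc1CNC(=O)n1c(N)nc2ccccc21` gives 68.4 nM.

Compound 3 holds the highest number of the three, which on this read-out means the weakest inhibition. Its nearest neighbour is compound 2, and the step between them reads a 1.2-fold higher number from compound 2 to compound 3 (0.09 log units; within the scatter), so the two cannot be told apart. The gap to compound 1 lies beyond the scatter, so compound 1 is the stronger inhibitor of that pair.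

Compound 4 `Nc1nc2ccccc2n1C(=O)NCc1ccccc1` differs from compound 3 by hydrogen in place of methyl on an aromatic carbon. The group that leaves sits on an aromatic carbon of a six-membered aromatic ring of carbon only, ortho to a large group; cut one bond further out, the change reads 2-methylphenyl to phenyl.

Going by the values given here, no measured step bears on this change: the only step available swaps an amino for a hydrogen on a different part of the molecule. With no guide of that kind, a small movement within the scatter, in no clear direction, is the most that can be expected.

Compound 4 is therefore expected to give about 70 nM in this assay, with a range from 30 nM to 160 nM. The estimate amounts to a step of a 1.0-fold higher number from compound 3 to compound 4 (0.01 log units; within the scatter), expected to stay within the scatter.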

Compound 4, half-maximal inhibitory concentration in the acid ceramidase assay: 29.3 nM
The estimate for compound 4 lay 2.4-fold (0.38 log units) above the measured number, and the stated range ends above it.
By their numbers in the acid ceramidase assay, from the lowest: compound 1; then compounds 4, 2 and 3 (each within the scatter of the next, the first and the last beyond it).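

In the acid ceramidase assay compound 3 gives 68.4 nM and compound 4 gives 29.3 nM. Going by these compounds alone, in the acid ceramidase assay, hydrogen in place of methyl on this aromatic carbon, ortho to a large group, gives a modest change beyond the scatter (a 2.3-fold lower number from compound 3 to compound 4 (0.37 log units; beyond the scatter)), the first evidence that this part of the molecule affects inhibition; the only earlier step (a 1.2-fold higher number from compound 2 to compound 3 (0.09 log units; within the scatter)) concerned an amino group elsewhere and stayed within the scatter. The methyl is therefore not required for inhibition in this pair, since the compound without it, the simple phenyl, is the stronger inhibitor of the two. In a physicochemical assay for metabolic stability, read by HPLC, at pH 4.5, tested at 10 uM (on this read-out lower numbers stand for a shorter-lived compound and higher numbers for a longer-lived compound), compound 3 gives 0.45 h and compound 4 gives 0.7 h. In the physicochemical assay, the same change stays within the scatter (a 1.6-fold higher number from compound 3 to compound 4 (0.19 log units; within the scatter)), so in this pair the stronger inhibition comes with no readable change in half-life.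

Nothing available explains the gain in inhibition, so the data show the size of the step but not its cause. Still open, going by these compounds, is whether a chlorine atom or a methoxy group on the same aromatic carbon would match hydrogen or methyl, and whether removing the methyl would have a similar effect in compound 2, which has no amino group.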